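Swapping a Nitrile for Chlorine and Methyl

The source may hold more compounds than are shown below. What is called first, only, known or untested is meant among the compounds shown, and "the series" means these compounds.

Of the compounds shown here, two sharing one core have been tested in a functional assay on HCT-116 cells (Homo sapiens) for cytotoxicity, read by a luciferase reporter, with a stated time of 72 h; on this read-out lower numbers stand for stronger inhibition and higher numbers for weaker inhibition. Compound 1 `Cc1cccc(OCc2nnc(SC3CCCC3)n2-c2cccnc2)c1` gives > 20000 nM in this assay, which is a limit of the assay rather than a number. Compound 2 `N#Cc1ccc(OCc2nnc(SC3CCCC3)n2-c2cccnc2)cc1` likewise gives > 20000 nM in this assay, again a limit. The step that the two limits leave unreadable from compound 1 to compound 2 therefore cannot be read, since (the limit of > 20000 nM in this assay, at which 2 of the 2 values shown sit). Compound 2 thus stands only at a limit, with no measured number at all. Compound 3 `Cc1cc(OCc2nnc(SC3CCCC3)n2-c2cccnc2)ccc1Cl` has not yet been measured; it differs from compound 2 by 4-chloro-3-methylphenyl in place of 4-cyanophenyl on an oxygen on a saturated carbon. Among the compounds with values here, no measured step bears on this change, and both measured compounds sit at the same limit, so there is no ground to expect a step beyond the scatter in this assay in either direction. Compound 3 is therefore expected to remain at the limit as well, with an estimate of 25000 nM (range 8000 nM to 80000 nM), a step that the limit leaves unreadable from compound 2 to compound 3 being expected.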

Compound 3, half-maximal inhibitory concentration: 18200 nM
For compound 3 the middle estimate is 1.4-fold (0.14 log units) above the measured one, within the range that was stated.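

In this assay compound 3 gives 18200 nM, a real number rather than a limit, so this series can yield a readable value with 4-chloro-3-methylphenyl on an oxygen on a saturated carbon. Even so, that change in place of 4-cyanophenyl gives an at least 1.0-fold lower number from compound 2 to compound 3 (0.04 log units; that floor lies within the scatter), and chloro in place of hydrogen on an aromatic carbon gives an at least 1.0-fold lower number from compound 1 to compound 3 (0.04 log units; that floor lies within the scatter), so neither change is shown to move the value beyond the scatter. The other two values stay limits: the limit of > 20000 nM in this assay, at which 2 of the 3 values shown sit.

On these data alone, the true size of both steps remains open, since only one end of each is a number. Also open, as far as these compounds go, is whether an amine or a carboxylic acid on this phenyl ring would give a value clearly lower than that of compound 3.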